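The compounds below may be only part of what the source reports. "The series", "measured", "known", "first", "only" and "open" are said of these compounds alone.

Compound 1 `O=C(NCCCCc1ccccc1)n1c(=O)oc2ccccc21` is the parent of this small set. Compound 1 gives 64 nM in an assay on HEK293 cells for inhibition of acid ceramidase (Homo sapiens), with a stated time of 10 min; a higher number here means a weaker inhibitor, a lower number a stronger inhibitor. That is the highest of the two numbers reported. Compound 3 `O=C(NCCCCc1ccccc1)n1c(=O)oc2ccc(Cl)cc21` is its nearest neighbour. In this assay compound 3 gives 15 nM, and the step of a 4.3-fold lower number from compound 1 to compound 3 (0.63 log units; beyond the scatter) came with a chloro in place of hydrogen on an aromatic carbon of the shared core. Compound 2 `Cc1cccc2oc(=O)n(C(=O)NCCCCc3ccccc3)c12` carries a methyl on that core; in this assay compound 2 gives no result reported.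

Compound 4 `O=C(NCCCCc1ccc([N+](=O)[O-])cc1)n1c(=O)oc2ccccc21` alters the other end of the molecule: nitro in place of hydrogen on an aromatic carbon. Going by the values given here, no measured step touches this six-membered ring of carbon only, so the chloro step of compound 3 bears on it only as a sign that the parent tolerates substitution without loss. A step of no more than the usual scatter is expected in this assay, in either direction. The estimate for compound 4 is 50 nM, within 20 nM to 160 nM, which is expected to mean a step of a 1.3-fold lower number from compound 1 to compound 4 (0.11 log units; within the scatter).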

Compound 4, half-maximal inhibitory concentration: 312 nM
Compound 4: the middle estimate sits 6.2-fold (0.80 log units) below what was measured; the whole stated range lies below it.
By their numbers in this assay, from the lowest: compound 3; then compound 1; then compound 4.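

With a 4.9-fold higher number from compound 1 to compound 4 (0.69 log units; beyond the scatter), the result shows that a nitro on this six-membered aromatic ring of carbon only, para to a large group, does not come without cost in this assay. Going by these compounds alone, this is the first measured change at this end of the molecule, and it runs opposite to the chloro step on the shared core, a 4.3-fold lower number from compound 1 to compound 3 (0.63 log units; beyond the scatter), so the tolerance seen there does not carry over to this ring. Nothing measured here accounts for the rise in the number.

The compounds shown leave open whether the rise belongs to the nitro itself or to any group at this place, since neither a fluoro nor an amine stands there for comparison. They also leave open how a nitro would behave elsewhere on this ring.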